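The source may hold more compounds than are shown below. What is called first, only, known or untested is meant among the compounds shown, and "the series" means these compounds.

Values in a functional assay on DU-145 cells (Homo sapiens) for inhibition, read by MTT assay, with a stated time of 48 h (on this read-out lower numbers stand for stronger inhibition and higher numbers for weaker inhibition), so far:
- compound 1 `Cn1c(/C=C2\SC(=O)N(CC(=O)N3CCOCC3)C2=O)nc2ccccc21` gives 41100 nM as a measured number
- compound 2 `CC(C)n1c(/C=C2\SC(=O)N(CC(=O)N3CCOCC3)C2=O)nc2ccccc21` gives > 50000 nM as a limit
- compound 3 `CCn1c(/C=C2\SC(=O)N(CC(=O)N3CCOCC3)C2=O)nc2ccccc21` gives > 50000 nM as a limit

Compound 1 is the only one of the three with a number, and the other two stand at the limit of > 50000 nM in this assay, at which 2 of the 3 values shown sit, in this short series.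

Compound 4 `CC1CN(C(=O)CN2C(=O)S/C(=C\c3nc4ccccc4n3C)C2=O)CC(C)O1` keeps the core of compound 1 and carries 2,6-dimethylmorpholin-4-yl in place of morpholin-4-yl on a carbonyl carbon, counted as 2,6-dimethylmorpholin-4-yl in place of morpholin-4-yl on a carbonyl carbon for this change.

Among the measured compounds shown here, no measured step touches that group. The steps of an at least 1.2-fold higher number from compound 1 to compound 2 (0.08 log units; that floor lies within the scatter) and an at least 1.2-fold higher number from compound 1 to compound 3 (0.08 log units; that floor lies within the scatter) both concern the group on the aromatic nitrogen, and both are only floors within the scatter.

The expectation therefore rests on compound 1 at 41100 nM as the single anchor. The estimated step is a 1.2-fold lower number from compound 1 to compound 4 (0.07 log units; within the scatter) with no direction expected beyond the scatter. By estimate, compound 4 is expected at 35000 nM within a range of 15000 nM to 70000 nM and has a fair chance of standing only as a limit.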

Compound 4, half-maximal inhibitory concentration: > 50000 nM
Compound 4: a limit, no number; the forecaster's own chance of this, stated with the estimate: 45%; middle value at least 1.4-fold (0.15 log units) away from the limit.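

In this assay compound 4 gives > 50000 nM, which is a limit and not a number. Among the compounds shown here, this is the first reading for a change on a carbonyl carbon rather than on the aromatic nitrogen, and 2,6-dimethylmorpholin-4-yl in place of morpholin-4-yl gives an at least 1.2-fold higher number from compound 1 to compound 4 (0.08 log units; that floor lies within the scatter), so no effect beyond the scatter can be claimed for this change. Compound 1 remains the only compound with a number, and the series gathers at one limit: the limit of > 50000 nM in this assay, at which 3 of the 4 values shown sit.

Going by these compounds, the true size of the step remains open, as does whether any replacement at this place gives a readable number. Piperidin-1-yl, piperazin-1-yl or an open-chain dimethylamino group in place of morpholin-4-yl would test whether this place can move the read-out at all.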